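Swapping a Piperazine Amide for an Ethyl Ester

A few compounds are considered here, and "the series" means these few. Any claim that something is new, unique, unknown or untested is made for them only; others in the source may bear on it.

compound 1 `CCCSc1nc(Cl)c2c(n1)N(Cc1ccccc1)C(C(=O)N1CCN(Cc3ccccc3)CC1)N2`: 51200 nM
compound 2 `CCCSc1nc(Cl)c2c(n1)N(Cc1cccs1)C(C(=O)N1CCN(C)CC1)N2`: 62300 nM
compound 3 `CCCSc1nc(Cl)c2c(n1)N(Cc1ccccc1)C(C(=O)N1CCN(C)CC1)N2`: > 64000 nM

All three measured compounds share one core and were tested in a functional assay on MGC-803 cells (Homo sapiens) for antiproliferative activity, read by MTT assay, with a stated time of 72 h; on this read-out lower numbers stand for stronger inhibition and higher numbers for weaker inhibition. Compound 1 gives 51200 nM and compound 2 gives 62300 nM, both weak. Going by these compounds, for compound 3 the assay reports only a limit, > 64000 nM, and no number, so compound 3 stands at the weak end of what was measured, and its exact position is unknown. The two steps that lead to it are small: an at least 1.2-fold higher number from compound 1 to compound 3 (0.09 log units; that floor lies within the scatter), and an at least 1.0-fold higher number from compound 2 to compound 3 (0.01 log units; that floor lies within the scatter); both floors lie within the scatter, and compound 3 sits at the limit of > 64000 nM in this assay, at which 1 of the 3 values shown sits.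

Compound 4 `CCCSc1nc(Cl)c2c(n1)N(Cc1ccccc1)C(C(=O)OCC)N2` differs from compound 3 in one place: ethoxy in place of 4-methylpiperazin-1-yl on a carbonyl carbon. Among the measured compounds shown here, no measured step touches this part of the molecule; the two known steps change groups elsewhere and were flat. There is therefore no basis for expecting a change beyond the scatter, and the step from compound 3 to compound 4 is estimated as a step that the limit leaves unreadable from compound 3 to compound 4. Compound 4 is thus expected to give about 70000 nM, with a range from 20000 nM to 200000 nM, and it may well again be reported only as a limit.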

Compound 4, half-maximal inhibitory concentration: 18500 nM
Beside the measured number, compound 4's estimate is 3.8-fold (0.58 log units) above it; measured number below the stated range.
By their numbers in this assay, from the lowest: compound 4; then compounds 1 and 2 (each within the scatter of the next). At a limit, above all of these: compound 3.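

The earlier steps shown here changed other parts of the molecule, and their floors lay within the scatter. In this assay, putting ethoxy in place of 4-methylpiperazin-1-yl on the carbonyl carbon gives an at least 3.4-fold lower number from compound 3 to compound 4 (0.53 log units; beyond the scatter), so this is the first place shown where a single change moves the number beyond the scatter, and the direction is towards stronger inhibition. The true size of this step cannot be given, because compound 3 is reported only as a limit: the limit of > 64000 nM in this assay, at which 1 of the 4 values shown sits.

The change swaps an amide for an ester and also removes a ring, so the pair cannot show which of these matters, or whether the number follows the smaller group, with 3 heavy atoms in place of 7. A simple diethylamino group on the same carbonyl carbon would keep the amide without the ring, while a methoxy group, a longer alkoxy chain or the free carboxylic acid would show how far the ester itself can be varied.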